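This account rests on a few compounds, and the source may have more. Where it says the series, first, only, none or still open, it means among the compounds named here.

Compound 2 `O=C(/C=C\Nc1ccc(Cl)cc1)c1nc(-c2ccc(C(F)(F)F)cc2)n2ccccc12` is the anchor of this small set. In a functional assay on HCT-116 cells (Homo sapiens) for cytotoxicity, read by MTT assay, with a stated time of 48 h (a higher number here means a weaker inhibitor, a lower number a stronger inhibitor), compound 2 gives 11500 nM. Compound 1 `COc1ccc(-c2nc(C(=O)/C=C\Nc3ccc(Cl)cc3)c3ccccn23)cc1` carries the change (methoxy in place of trifluoromethyl on an aromatic carbon). For compound 1 this assay reports only a limit, > 30000 nM. The step of an at least 2.6-fold higher number from compound 2 to compound 1 (0.41 log units; beyond the scatter) is therefore bounded from one side only, as the limit of > 30000 nM in this assay, at which 2 of the 3 values shown sit, shows. Compound 3 `O=C(/C=C\Nc1ccc(F)cc1)c1nc(-c2ccc(C(F)(F)F)cc2)n2ccccc12` differs from compound 2 by fluoro in place of chloro on an aromatic carbon. For compound 3 this assay again reports only a limit, > 30000 nM. The step of an at least 2.6-fold higher number from compound 2 to compound 3 (0.41 log units; beyond the scatter) is likewise one-sided. Compound 4 `COc1ccc(-c2nc(C(=O)/C=C\Nc3ccc(F)cc3)c3ccccn23)cc1` has not yet been measured; it differs from compound 3 by methoxy in place of trifluoromethyl on an aromatic carbon, the same change that was made from compound 2 to compound 1, at the same place. That earlier step weakened inhibition, and compound 3 already sits at the limit of this assay with > 30000 nM, so for compound 4 the step that the limit leaves unreadable from compound 3 to compound 4 is expected to leave it at or beyond that limit. The estimate for compound 4 in this assay is 60000 nM, most likely reported only as a limit, with an expected range from 25000 nM to 200000 nM.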

Compound 4, half-maximal inhibitory concentration: > 30000 nM
Compound 4 gave a limit, no number; the forecaster's own chance of this, stated with the estimate: 90%; the middle value does not contradict the limit.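

Compound 4 gives only a limit, as do compound 1 and compound 3, so the steps from compound 3 and from compound 1 to compound 4 cannot be read, because all three sit at the same limit: the limit of > 30000 nM in this assay, at which 3 of the 4 values shown sit.

The compounds shown leave open how far apart compound 1, compound 3 and compound 4 truly lie.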